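The source may hold more compounds than are shown below. What is called first, only, known or untested is meant among the compounds shown, and "the series" means these compounds.

Measured compounds:
Compound 1, `O=C(O)CCCC/C=C(\c1cccnc1)c1ccsc1`, in an assay (Equus caballus) for inhibition of Thromboxane-A synthase (Homo sapiens), using microsomes (a lower number here means a stronger inhibitor, a higher number a weaker inhibitor), gives 31 nM.
Compound 2, `O=C(O)CCCC/C=C(\c1cccnc1)c1cccc([N+](=O)[O-])c1`, in this assay gives 73 nM.
Compound 3, `O=C(O)CCCC/C=C(\c1cccnc1)c1cccs1`, in this assay gives 20 nM.

Compound 3 has the lowest number of the three in this assay. Its nearest neighbour is compound 1, from which the step of a 1.6-fold lower number from compound 1 to compound 3 (0.19 log units; within the scatter) lies within the scatter, so the two cannot be ranked against each other. Compound 2 stands further away, with a number that is beyond the scatter from that of compound 3.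

Compound 4, `O=C(O)CCCC/C=C(\c1cccnc1)c1cccc(F)c1`, is not yet measured. It differs from compound 3 in one place: 3-fluorophenyl in place of thiophen-2-yl on a double-bonded chain carbon bound to an aromatic carbon and a double-bonded chain carbon.

Among the compounds with values here, only one measured step exists, and it exchanges one thiophenyl isomer for the other, so it does not speak to replacing a five-membered ring by a six-membered one. Within the data shown here, the pair compound 2 and compound 3 does show that a six-membered ring of carbon carrying a nitro group gives a higher number than thiophen-2-yl, though no step for that pair is given. On that basis compound 4 is expected to give a number in this assay of about 40 nM, with a range from 15 nM to 120 nM, which would be the step of a 2.0-fold higher number from compound 3 to compound 4 (0.30 log units; within the scatter).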

Compound 4, half-maximal inhibitory concentration: 55 nM
For compound 4 the middle estimate is 1.4-fold (0.14 log units) below the measured one; the measured number falls inside the stated range.
By their numbers in this assay, from the lowest: compounds 3, 1, 4 and 2 (each within the scatter of the next, the first and the last beyond it).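

In this assay, within the data shown here, the step from the five-membered ring to the six-membered one at this double-bonded chain carbon is the first change here printed as beyond the scatter, at a 2.8-fold higher number from compound 3 to compound 4 (0.44 log units; beyond the scatter), so the group on this carbon can shift the number, although only modestly. That separation holds for thiophen-2-yl alone: the other ring isomer gives a 1.8-fold higher number from compound 1 to compound 4 (0.25 log units; within the scatter), which lies within the scatter, so compound 1 and compound 4 cannot be ranked, and the same 3-fluorophenyl lands clear of one thiophenyl isomer but not of the other. The exchange on the aromatic carbon of the six-membered ring also cannot be ranked, at a 1.3-fold lower number from compound 2 to compound 4 (0.12 log units; within the scatter), so fluoro and nitro are not told apart in these data.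

Going by these compounds, it remains open whether an unsubstituted phenyl, or a ring carrying chloro or an amine on that aromatic carbon, would stand with the thiophenyl compounds or with compound 4. The compounds shown also leave open how any of these rings behaves with a longer chain, or with an amide in place of the carboxylic acid. No measurement of any other kind is available to bear on this result.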